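The source may hold more compounds than are shown below. What is called first, only, known or untested is meant among the compounds shown, and "the series" means these compounds.

In a functional assay on MDA-MB-231 cells (Homo sapiens) for antiproliferative activity, read by MTT assay, with a stated time of 24 h (a lower number here means a stronger inhibitor, a higher number a weaker inhibitor), compound 1 `COc1ccc(-c2noc(-c3ccc(F)cc3)n2)cc1OC1CCCC1` gives 55500 nM. Compound 2 `COc1ccc(-c2noc(-c3cccnc3)n2)cc1OC1CCCC1` stands at > 1000000 nM, which is a limit of the assay and not a number, so its true position is not known. Compound 3 `COc1ccc(-c2noc(-c3ccc(O)cc3)n2)cc1OC1CCCC1` differs from compound 2 at a single place: 4-hydroxyphenyl in place of pyridin-3-yl on an aromatic carbon. It carries 4-hydroxyphenyl in place of pyridin-3-yl on an aromatic carbon of the five-membered aromatic ring with 2 nitrogen and 1 oxygen.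

Among the measured compounds shown here, only one measured step bears on this change. That step, an at least 18-fold higher number from compound 1 to compound 2 (1.25 log units; beyond the scatter), is large and lies beyond the scatter, and it came with pyridin-3-yl taking the place of 4-fluorophenyl. The new change runs the other way, removing pyridin-3-yl and restoring a six-membered aromatic ring of carbon only, as in compound 1. For the measured compounds named here, no measured step tests the 4-hydroxyphenyl group itself, so the expectation remains loose. The expected change is a large one toward a lower number in this assay, an at least 14-fold lower number from compound 2 to compound 3 (1.15 log units; beyond the scatter). Compound 3 is estimated at 70000 nM, with an expected range of 15000 nM to 350000 nM.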

Compound 3, half-maximal inhibitory concentration: 310 nM
For compound 3 the middle estimate is 230-fold (2.35 log units) above the measured one, outside the stated range (below it).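

In this assay, 4-hydroxyphenyl in place of pyridin-3-yl gives an at least 3200-fold lower number from compound 2 to compound 3 (3.50 log units; beyond the scatter), so this position on the five-membered aromatic ring can carry a group that gives a far lower number than either earlier compound had suggested. Compound 2 stands at a limit of the assay and not a number, so this step has a bound on one side only and its true size is unknown: the limit of > 1000000 nM in this assay, at which 1 of the 3 values shown sits.

The firmer comparison is hydroxy in place of fluoro, which gives a 180-fold lower number from compound 1 to compound 3 (2.25 log units; beyond the scatter); since compound 1 and compound 3 both carry a six-membered aromatic ring of carbon only at this place, having such a ring is not enough by itself, and the group on that ring makes a large difference.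

As far as these compounds go, whether a methoxy or an amino group in place of the hydroxy would keep a number like that of compound 3 stays open. So does where a plain phenyl would stand relative to compound 1 and compound 3, and whether the same change would hold on a core with a longer chain in place of the cyclopentyloxy group.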